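The source may report more compounds than this note shows. Statements on the series, on what has been measured and on what is new or still open speak of the compounds shown alone.

Of the compounds shown here, three built on the same core have been tested in a functional assay on 4T1 cells (Mus musculus) for cytotoxicity, read by MTT assay, with a stated time of 24 h; a lower number here means a stronger inhibitor, a higher number a weaker inhibitor. Compound 1, `O=C1/C(=C/c2ccccc2F)CN(C(=S)SCc2cn(Cc3ccc(F)cc3)nn2)C/C1=C\c1ccccc1F`, gives 9900 nM in this assay, which is the higher of the two numbers recorded. Compound 2, `O=C1/C(=C/c2ccccc2F)CN(Cc2cn(Cc3ccc(F)cc3)nn2)C/C1=C\c1ccccc1F`, gives 6400 nM in this assay, and this number lies within the usual scatter of the number for compound 1, so the two cannot be told apart. Compound 3, `COc1ccc(/C=C2\CN(C(=S)SCc3cn(Cc4ccccc4Cl)nn3)C/C(=C\c3ccc(OC)cc3)C2=O)cc1`, reaches only a limit of this assay, reported as > 100000 nM. For compound 3 this is the limit of > 100000 nM in this assay, at which 1 of the 3 values shown sits.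

Compound 4, `O=C1/C(=C/c2ccccc2F)CN(C(=S)SCc2cn(Cc3cccc(Cl)c3)nn2)C/C1=C\c1ccccc1F`, has not yet been measured in this assay. Compared with compound 1 it carries 3-chlorophenyl in place of 4-fluorophenyl on a saturated chain carbon bound to an aromatic nitrogen. Within the data shown here, no measured pair among the three compounds differs only in this way, so there is no measured step to lean on. A swap of one substituted benzyl group for another of the same size on a saturated chain carbon bound to an aromatic nitrogen is expected to leave the number within the scatter, and the step of a 1.0-fold higher number from compound 1 to compound 4 (0.00 log units; within the scatter) is accordingly expected to be small, in no clear direction. Compound 4 is therefore estimated at 10000 nM in this assay, with a range from 3000 nM to 40000 nM.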

Compound 4, half-maximal inhibitory concentration: > 100000 nM
Compound 4: a limit, no number (the forecaster's own chance of this, stated with the estimate: 15%); middle value at least 10-fold (1.00 log units) away from the limit.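

Before this result, no measured pair differed only at this position, so nothing showed whether the group there mattered. Replacing 4-fluorophenyl with 3-chlorophenyl on a saturated chain carbon bound to an aromatic nitrogen now gives, in this assay, an at least 10-fold higher number from compound 1 to compound 4 (1.00 log units; beyond the scatter). The two groups have the same count of heavy atoms and each holds one six-membered aromatic ring of carbon, yet this position clearly does not tolerate every such swap, and compound 4 stands at a limit of the assay rather than at a number, so the step fixes only the smallest possible size of the change: the limit of > 100000 nM in this assay, at which 2 of the 4 values shown sit.

This single change alters both the halogen and its place on the ring, and the compounds shown cannot separate the two, which a pair such as 4-chlorophenyl and 3-fluorophenyl at this position could begin to do. From the compounds shown here alone, it also remains open how a plain phenyl group would behave here, and whether the same swap would have a similar effect on the shorter link of compound 2, which lacks the sulfur-bearing carbon group of compound 1.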